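Methoxy added to compound 1: working notes

The compounds below may be only part of what the source reports. "The series", "measured", "known", "first", "only" and "open" are said of these compounds alone.

- compound 1 `O=C(/C=C/c1ccc(/C=C/C(=O)c2ccc3ccccc3c2)o1)NO` gives 2220 nM
- compound 2 `O=C(/C=C/c1ccc(/C=C/C(=O)c2ccc(Cl)cc2)o1)NO` gives 2010 nM
- compound 3 `O=C(CCCCCCC(=O)Nc1ccccc1C(=O)NO)Nc1ccccc1` gives 2690 nM

All three values come from a functional assay on HCT-116 cells (Homo sapiens) for antiproliferative activity, read by MTT assay, with a stated time of 48 h; a higher number here means a weaker inhibitor, a lower number a stronger inhibitor. Compound 1 sits level with both compound 2 and compound 3, all within the scatter. Compound 4 `COc1ccc2cc(C(=O)/C=C/c3ccc(/C=C/C(=O)NO)o3)ccc2c1` departs from compound 1 by one change: methoxy in place of hydrogen on an aromatic carbon. Within the data shown here, no measured pair differs in one place, so the series offers no direct guide to this change. In this assay the expected outcome is no step beyond the scatter, in either direction. The estimated 1.2-fold lower number from compound 1 to compound 4 (0.09 log units; within the scatter) stays within that scatter. Compound 4 is expected at 1800 nM, with an estimated range from 800 nM to 4000 nM as the working bounds.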

Compound 4, half-maximal inhibitory concentration: 2060 nM
Estimate against measurement, compound 4: 1.1-fold (0.06 log units) below, and the stated range covers the measured number.
By their numbers in this assay, from the lowest: compounds 2, 4, 1 and 3 (each within the scatter of the next).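

In this assay, among these compounds, methoxy in place of hydrogen on an aromatic carbon gives the first step that differs in one place: a 1.1-fold lower number from compound 1 to compound 4 (0.03 log units; within the scatter). At this position, on a six-membered aromatic ring of carbon only that is part of a fused or bridged system of two rings, the methoxy group therefore leaves the number within the scatter. Nothing available explains this outcome.

As far as these compounds go, whether a hydroxy group, an amine or a longer alkoxy chain at the same carbon would also stay within the scatter remains open. So does the outcome of methoxy on other carbons of the same ring system.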